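The source may report more compounds than this note shows. Statements on the series, on what has been measured and on what is new or still open speak of the compounds shown alone.

Working notes on the step from compound 2 `CCOC(=O)C(COC(=O)/C=C/c1ccc(OC)c(OC)c1)c1ccc(F)cc1` to compound 4 `CCOC(=O)C(COC(=O)/C=C/c1ccc(OC)c(OC)c1)c1ccc(C(F)(F)F)cc1`. In a functional assay on A2780 cells (Homo sapiens) for cytotoxicity, read by MTT assay, with a stated time of 72 h (a lower number here means a stronger inhibitor, a higher number a weaker inhibitor), compound 2 gives > 0.01 ug/mL, which is a limit and not a number. Compound 1 `CCOC(=O)C(COC(=O)c1ccccc1OC(C)=O)c1ccc(F)cc1` gives > 0.01 ug/mL, also a limit. Compound 3 `CCOC(=O)C(COC(=O)c1ccccc1OC(C)=O)c1ccc(C(F)(F)F)cc1` gives > 0.01 ug/mL, again a limit. All the measured compounds therefore stand at the limit of > 0.01 ug/mL in this assay, at which 3 of the 3 values shown sit, and compound 2 has no readable place among them.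

The structural change is trifluoromethyl in place of fluoro on an aromatic carbon, para to a large group. Among the measured compounds shown here, one measured step bears on it, the same exchange, which gave a step that the two limits leave unreadable from compound 1 to compound 3. No size or direction can be carried over from that step, so no change beyond the scatter is expected in this assay. The step expected is a step that the limit leaves unreadable from compound 2 to compound 4. For compound 4 the estimated value is 0.02 ug/mL, with an expected range of 0.01 ug/mL to 0.1 ug/mL, and a further report as a limit is the likeliest outcome.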

Compound 4, half-maximal inhibitory concentration: > 0.01 ug/mL
Compound 4: only a limit was reported (the forecaster's own chance of this, stated with the estimate: 85%); the middle value is on the limit's open side.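

In this assay compound 4 gives > 0.01 ug/mL, which is a limit and not a number, so no step can be read from compound 2 to compound 4. The compounds shown leave open whether trifluoromethyl in place of fluoro shifts the potency at all: the limit of > 0.01 ug/mL in this assay, at which 4 of the 4 values shown sit.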